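Propoxy for sec-butyl on the anilide ring of compound 1

The source may hold more compounds than are shown below. What is called first, only, known or untested is meant among the compounds shown, and "the series" means these compounds.

Compound 1 `CCC(C)c1ccc(Nc2nc(C)cs2)cc1` gives 0% in an ADME assay on microsomes from liver (Rattus norvegicus) for metabolic stability, with a stated time of 30 min, tested at 1 uM; a lower number here means that less of the compound is left, a higher number that more of the compound is left. Compound 2 `Cc1csc(Nc2ccc(C(C)C)cc2)n1` gives 0%, and compound 3 `Cc1csc(Nc2ccc(C(C)(C)O)cc2)n1` gives 12%. Compound 1 thus stands level with compound 2 at the digits shown, the two together the lowest of the three numbers; the step of no change at the digits printed from compound 1 to compound 2 (within the scatter) is within the scatter, while a number 12 percentage points higher from compound 1 to compound 3 (beyond the scatter) and a number 12 percentage points higher from compound 2 to compound 3 (beyond the scatter) are modest rises.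

Compound 4 `CCCOc1ccc(Nc2nc(C)cs2)cc1` is not yet measured. Against compound 1 the change is propoxy in place of sec-butyl on an aromatic carbon. Among the compounds with values here, the only measured step that exchanges the whole group on that aromatic carbon is a number 12 percentage points higher from compound 1 to compound 3 (beyond the scatter), which brought in a hydrogen-bond acceptor at the same place; the change to compound 4 likewise brings in one hydrogen-bond acceptor but no donor. On that basis a small rise is expected, a number 8 percentage points higher from compound 1 to compound 4 (within the scatter), with the low value of compound 1 in this assay as the floor. Compound 4 is estimated at 8%, with a range from 0% to 25%.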

Compound 4, percent of the compound remaining: 4%
Estimate against measurement, compound 4: 4 percentage points above; measured number inside the range.
By their numbers in this assay, from the lowest: compounds 1, 2, 4 and 3 (each within the scatter of the next, the first and the last beyond it).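

In this assay propoxy on this aromatic carbon cannot be told apart from sec-butyl or isopropyl, with a number 4 percentage points higher from compound 1 to compound 4 (within the scatter) and a number 4 percentage points higher from compound 2 to compound 4 (within the scatter) as the steps, so the hydrogen-bond acceptor that enters with propoxy does not by itself give a change beyond the scatter. Against 1-hydroxy-1-methylethyl the step is a number 8 percentage points lower from compound 3 to compound 4 (within the scatter) and compound 4 also stays within the scatter of compound 3, which leaves compound 4 inseparable from both ends of the series, although compound 3 stands apart from compounds 1 and 2. No measurement at hand bears on the reason for these numbers.

On these data alone, whether methoxy, an amine or a carboxylic acid on this aromatic carbon would leave more of the compound than compound 3 stays open. The compounds shown vary only this one place, so the effect of changes on the shared core also remains open.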